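Moving the bromine on the amide-bearing ring

The source may hold more compounds than are shown below. What is called first, only, known or untested is meant among the compounds shown, and "the series" means these compounds.

Three compounds have been measured in an assay on CHO cells, read by calcium flux; a lower number here means a stronger inhibitor, a higher number a weaker inhibitor:

Compound 1, `CC(C)c1ccc(NC(=O)c2csc(Cc3c(Cl)cccc3Cl)n2)cc1`: 520 nM
Compound 2, `CN(C)c1ccc(NC(=O)c2csc(Cc3c(Cl)cccc3Cl)n2)cc1`: 1270 nM
Compound 3, `O=C(Nc1ccc(Br)cc1)c1csc(Cc2c(Cl)cccc2Cl)n1`: 460 nM

Compound 3 has the lowest of the three numbers. Its gap to compound 1 is small, a 1.1-fold lower number from compound 1 to compound 3 (0.05 log units; within the scatter), so these two cannot be told apart; the gap to compound 2, a 2.8-fold lower number from compound 2 to compound 3 (0.44 log units; beyond the scatter), is beyond the scatter. Compound 4, `O=C(Nc1ccccc1Br)c1csc(Cc2c(Cl)cccc2Cl)n1`, keeps the same atoms and differs from compound 3 in one place: 2-bromophenyl in place of 4-bromophenyl on an amide-type nitrogen.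

Among the measured compounds shown here, none of the measured steps bears directly on this change. Each of them, a 2.4-fold higher number from compound 1 to compound 2 (0.39 log units; beyond the scatter) and a 2.8-fold lower number from compound 2 to compound 3 (0.44 log units; beyond the scatter), exchanges one group for another on the aromatic carbon, whereas here the bromine itself is retained and only the shape of the bromophenyl changes. Those steps show that changes on this ring shift the number by modest amounts at most. A modest shift in either direction is therefore plausible, with the number more likely to rise than to fall; the expected step is a 1.7-fold higher number from compound 3 to compound 4 (0.24 log units; within the scatter). Compound 4 is estimated at 800 nM, within 250 nM to 2500 nM.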

Compound 4, half-maximal inhibitory concentration: > 4000 nM
Compound 4 was reported as a limit (the forecaster's own chance of this, stated with the estimate: 5%); middle value at least 5.0-fold (0.69 log units) from the limit.
By their numbers in this assay, from the lowest: compounds 3 and 1 (each within the scatter of the next); then compound 2. At a limit, above all of these: compound 4.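

The change from 4-bromophenyl to 2-bromophenyl on the amide-type nitrogen gives an at least 8.6-fold higher number from compound 3 to compound 4 (0.93 log units; beyond the scatter) in this assay. Compound 4 is reported as a limit rather than a number: the limit of > 4000 nM in this assay, at which 1 of the 4 values shown sits. The earlier steps shown here exchanged one group for another on the aromatic carbon and stayed modest at most, such as a 2.8-fold lower number from compound 2 to compound 3 (0.44 log units; beyond the scatter), whereas this one shows that moving the bromine alone, with the same atoms, can matter more than those exchanges.

As far as these compounds go, whether the same large rise would follow with another group placed as the bromine is in 2-bromophenyl, such as fluoro, methoxy or isopropyl, remains open. A plain phenyl on the amide-type nitrogen would show how each bromophenyl compares with the ring carrying no bromine at all.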